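The source may hold more compounds than are shown below. What is called first, only, known or untested is meant among the compounds shown, and "the series" means these compounds.

Compound 1 `CCOc1cc(-c2ccccc2)nc2ccccc12`, compound 2 `c1ccc(COc2cc(-c3ccccc3)nc3ccccc23)cc1` and compound 3 `CCCCOc1cc(-c2ccccc2)nc2ccccc12` share one core. In a functional assay on L1210 (1565) cells (Mus musculus) for cytotoxicity (on this read-out lower numbers stand for an effect already at smaller amounts and higher numbers for an effect only at larger amounts of compound), compound 1 gives > 10 ug/mL, which is a limit and not a number. Compound 2 gives > 10 ug/mL, also a limit. On these data alone, compound 3 gives > 10 ug/mL, again a limit, so its true value stays unknown.

Compound 4 `CC(C)COc1cc(-c2ccccc2)nc2ccccc12` differs from compound 3 by one change: isopropyl in place of propyl on a saturated chain carbon bound to an oxygen on an aromatic ring.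

For the measured compounds named here, three measured steps bear on this: a step that the two limits leave unreadable from compound 1 to compound 2, a step that the two limits leave unreadable from compound 1 to compound 3 and a step that the two limits leave unreadable from compound 2 to compound 3. None offers a size to carry over, so no step beyond the scatter and no direction is expected in this assay, because the limit of > 10 ug/mL in this assay, at which 3 of the 3 values shown sit, is all these compounds show. The expected step is a step that the limit leaves unreadable from compound 3 to compound 4. Compound 4 is estimated at 15 ug/mL, with an expected range of 7 ug/mL to 40 ug/mL.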

Compound 4, half-maximal effective concentration: > 10 ug/mL
Compound 4: no number, only a limit; the forecaster's own chance of this, stated with the estimate: 85%; the middle value lies beyond the limit too.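

Compound 4 gives only a limit, as do compound 1, compound 2 and compound 3, so no step among these four compounds can be read. On these data alone, how far apart their true values lie in this assay stays open.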